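Notes on the carbonyl substituent series, up to compound 4

The compounds below may be only part of what the source reports. "The series", "measured", "known", "first", "only" and "open" are said of these compounds alone.

Measured in a functional assay on MGC-803 cells (Homo sapiens) for cytotoxicity, read by MTT assay, with a stated time of 72 h; a higher number here means a weaker inhibitor, a lower number a stronger inhibitor:
- compound 1 `C=C1C(=O)[C@@]23C(=O)OC[C@]4(C(=O)CCC(C)(C)[C@H]4C=O)[C@@H]2CC[C@@H]1[C@H]3OC(C)=O`: 1660 nM
- compound 2 `C=C1C(=O)[C@@]23C(=O)OC[C@]4(C(=O)CCC(C)(C)[C@H]4C=O)[C@@H]2CC[C@@H]1[C@H]3OC(=O)c1ccccc1`: 1920 nM
- compound 3 `C=C1C(=O)[C@@]23C(=O)OC[C@]4(C(=O)CCC(C)(C)[C@H]4C=O)[C@@H]2CC[C@@H]1[C@H]3OC(=O)c1ccc(C)cc1`: 2240 nM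

Compound 3, at 2240 nM, cannot be separated from the other two compounds: a 1.2-fold higher number from compound 2 to compound 3 (0.07 log units; within the scatter), and a 1.3-fold higher number from compound 1 to compound 3 (0.13 log units; within the scatter).

The next compound is compound 4 `C=C1C(=O)[C@@]23C(=O)OC[C@]4(C(=O)CCC(C)(C)[C@H]4C=O)[C@@H]2CC[C@@H]1[C@H]3OC(=O)c1ccc(OC)cc1`, which differs from compound 3 by methoxy in place of methyl on an aromatic carbon. This places methoxy in place of methyl on an aromatic carbon, para to a large group.

The closest measured precedent is a 1.2-fold higher number from compound 2 to compound 3 (0.07 log units; within the scatter), which is methyl in place of hydrogen on that same aromatic carbon. The larger replacements on the carbonyl carbon give a 1.2-fold higher number from compound 1 to compound 2 (0.06 log units; within the scatter) and a 1.3-fold higher number from compound 1 to compound 3 (0.13 log units; within the scatter). All three steps stay within the scatter, and none of the three compounds goes against this. For the measured compounds named here, no measured compound yet carries a methoxy group, so the series does not test this group directly.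

No step beyond the scatter is expected in this assay, and no direction is favoured, so the expected change is only a 1.1-fold lower number from compound 3 to compound 4 (0.03 log units; within the scatter). For compound 4 the estimated value is 2100 nM, with an expected range from 1300 nM to 3400 nM.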

Compound 4, half-maximal inhibitory concentration: 1870 nM
Compound 4: middle estimate off by 1.1-fold (0.05 log units), on the high side, and the stated range covers the measured number.
By their numbers in this assay, from the lowest: compounds 1, 4, 2 and 3 (each within the scatter of the next).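

In this assay, the para position of the aromatic ring now has an oxygen-linked group, and the step of a 1.2-fold lower number from compound 3 to compound 4 (0.08 log units; within the scatter) shows that methoxy in place of methyl cannot be told apart from it, while the step of a 1.0-fold lower number from compound 2 to compound 4 (0.01 log units; within the scatter) shows the same for methoxy in place of hydrogen on that aromatic carbon. The earlier compounds shown here tested only hydrogen and methyl on this carbon, so the tolerated set now includes a substituent that brings a hydrogen-bond acceptor, with no compound going against this. The full replacement on the carbonyl carbon also remains unresolved, with the step of a 1.1-fold higher number from compound 1 to compound 4 (0.05 log units; within the scatter) showing 4-methoxyphenyl in place of methyl as no more separable than phenyl or 4-methylphenyl, and no supporting measurement bears on this result.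

From the compounds shown here alone, what remains open is whether an amine or a carboxylic acid on that aromatic carbon, or a longer chain in place of methyl on the carbonyl carbon, would give a step beyond the scatter. All four compounds keep the shared core unchanged, so these numbers say nothing about how the core itself bears on the read-out.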